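Methyl for chloro on a quinolinone amide

The source may report more compounds than this note shows. Statements on the series, on what has been measured and on what is new or still open speak of the compounds shown alone.

Measured compounds:
compound 1, `Cc1cc(=O)[nH]c2cc(NC(=O)c3cccc4ccccc34)ccc12`, 1.72
compound 2, `Cc1cc(O)nc2cc(N)ccc12`, 0.793
compound 3, `Cc1cc(=O)[nH]c2cc(NC(=O)c3ccccc3Cl)ccc12`, 1.55

In a physicochemical assay for lipophilicity (a lower number here means a more polar compound, a higher number a more lipophilic compound), compound 3 gives 1.55. That number lies close to the value of compound 1, 1.72, the two being within the scatter of each other, and it is separated from the value of compound 2, 0.793, by a gap that is beyond the scatter, with compound 2 giving the lower number of the two. Compound 3 therefore sits among the more lipophilic members of the three, with no separation from compound 1 that the measurement can resolve.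

Compound 4, `Cc1ccccc1C(=O)Nc1ccc2c(C)cc(=O)[nH]c2c1`, differs from compound 3 in one place: methyl in place of chloro on an aromatic carbon. The exchange sits on an aromatic carbon of a six-membered aromatic ring of carbon only, ortho to a large group, so that 2-chlorophenyl becomes 2-methylphenyl. Nothing else in the structure moves.

Going by the values given here, no measured pair here shows this exchange, so the step can only be expected. A step from compound 3 to compound 4 of a number 0.10 log units lower from compound 3 to compound 4 (within the scatter) is expected in this assay, a small downward shift that stays within the scatter. Compound 4 is therefore estimated at 1.45, with a range from 1.15 to 1.75.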

Compound 4, partition coefficient: 1.71
Beside the measured number, compound 4's estimate is 0.26 log units below it; the measured number falls inside the stated range.
By their numbers in this assay, from the lowest: compound 2; then compounds 3, 4 and 1 (each within the scatter of the next).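

In this assay, the exchange of chloro for methyl on an aromatic carbon, ortho to a large group, gives a number 0.16 log units higher from compound 3 to compound 4 (within the scatter). Going by these compounds alone, this is the first pair here that differs in only one place, and it shows that this measurement cannot tell 2-chlorophenyl from 2-methylphenyl at this position, even though the group that enters holds a carbon in place of a chlorine. No measurement at hand offers an explanation for this result.

The compounds shown leave open whether a methoxy group, an amine or a carboxylic acid at the same position would also stay within the scatter of compound 3. They also leave open whether the same exchange would give a similar step elsewhere on that ring.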